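Shortening the ester chain on an arabinosyl cytosine nucleoside

This account rests on a few compounds, and the source may have more. Where it says the series, first, only, none or still open, it means among the compounds named here.

Measured compounds:
- compound 1, `C=CCCCCCCCCC(=O)O[C@H]1[C@H](O)[C@H](n2ccc(N)nc2=O)O[C@@H]1CO`: 0.05 ug/mL
- compound 2, `CCCCCCC/C=C\C(=O)O[C@H]1[C@H](O)[C@H](n2ccc(N)nc2=O)O[C@@H]1CO`: 0.06 ug/mL
- compound 3, `CCCCCCCCCC(=O)O[C@H]1[C@H](O)[C@H](n2ccc(N)nc2=O)O[C@@H]1CO`: 0.09 ug/mL

All three were tested in a functional assay on HeLa cells (Homo sapiens) for cytotoxicity, read by cell counting, with a stated time of 48 h; on this read-out higher numbers stand for an effect only at larger amounts of compound and lower numbers for an effect already at smaller amounts. Compound 3, `CCCCCCCCCC(=O)O[C@H]1[C@H](O)[C@H](n2ccc(N)nc2=O)O[C@@H]1CO`, gives 0.09 ug/mL, the highest of the three numbers, but its nearest neighbours lie close: a 1.5-fold higher number from compound 2 to compound 3 (0.18 log units; within the scatter) and a 1.8-fold higher number from compound 1 to compound 3 (0.26 log units; within the scatter). Both steps change only the acyl chain of the ester and both stay within the scatter, so among these three nothing can be ordered.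

Compound 4, `CC(=O)O[C@H]1[C@H](O)[C@H](n2ccc(N)nc2=O)O[C@@H]1CO`, has not been measured. It differs from compound 3 by hydrogen in place of octyl on a saturated chain carbon bound to a carbonyl carbon. This removes almost the whole ester chain, leaving an acetyl ester in place of a decanoyl ester on the same core.

The two measured steps bear on it only loosely: they show that moving a methyl for a vinyl on the chain, or swapping one nine-carbon group for another, leaves the number unchanged within scatter. Neither step removes an octyl. The account therefore expects a larger change for compound 4 than either measured step, with the number moving upward, as an 11-fold higher number from compound 3 to compound 4 (1.05 log units; beyond the scatter). Compound 4 is estimated at 1 ug/mL, with a range from 0.1 ug/mL to 8 ug/mL.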

Compound 4, concentration for half-maximal effect: 0.14 ug/mL
Beside the measured number, compound 4's estimate is 7.1-fold (0.85 log units) above it; the measured number falls inside the stated range.
By their numbers in this assay, from the lowest: compounds 1, 2, 3 and 4 (each within the scatter of the next, the first and the last beyond it).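

Cutting the octyl away leaves no readable change in this assay: a 1.6-fold higher number from compound 3 to compound 4 (0.19 log units; within the scatter), so at this position the saturated decanoyl ester can give way to an acetyl ester without a measurable shift, something the earlier steps could not show because each of them kept a long chain in place. The two unsaturated chains do separate from the acetyl ester, with a 2.3-fold higher number from compound 2 to compound 4 (0.37 log units; beyond the scatter) and a 2.8-fold higher number from compound 1 to compound 4 (0.45 log units; beyond the scatter), but both steps are modest. Compound 3 lies within the scatter of compound 1, compound 2 and compound 4, so the chains shown form no graded series, and nothing on hand explains these small differences.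

The compounds shown leave open whether a longer chain than the decanoyl, or an amine or a carboxylic acid at the end of the chain, would keep the number in this narrow range. They also leave open whether the intact esters or some product formed from them during the assay accounts for the effect on the cells, and how the shared core performs with a free hydroxyl in place of the ester.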